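The source may hold more compounds than are shown below. What is called first, only, known or untested is meant among the compounds shown, and "the series" means these compounds.

Among the compounds with values here, in an ADME assay on microsomes from liver (Homo sapiens) for metabolic stability (a higher number here means faster removal of the compound, a lower number slower removal), two closely related compounds have numbers so far. Compound 1 `CC(=O)N[C@@H]1CCC[C@H](C(=O)Nc2cc(-c3cnn4c3CCCC4)c(Cl)cn2)C1` gives 17 mL.min-1.g-1 and compound 2 `CC(=O)N[C@@H]1CCC[C@H](C(=O)Nc2cc(-c3cnn4c3CCCCC4)c(Cl)cn2)C1` gives 39 mL.min-1.g-1 as the higher of the two. Compound 3 `CC(=O)N[C@@H]1CCC[C@H](C(=O)Nc2cc(-c3cnn4c3CN(C)CC4)c(Cl)cn2)C1` is still unmeasured. Its difference from compound 2, (a group of 10 heavy atoms (7 carbon, 3 nitrogen; one five-membered aromatic ring with 2 hetero atoms, one six-membered non-aromatic ring with 2 hetero atoms) in place of a group of 10 heavy atoms (8 carbon, 2 nitrogen; one five-membered aromatic ring with 2 hetero atoms, one seven-membered non-aromatic ring with 1 hetero atom), on an aromatic carbon), lies on an aromatic carbon opposite the ring nitrogen. Within the data shown here, only one measured step bears on this change: a 2.3-fold higher number from compound 1 to compound 2 (0.36 log units; beyond the scatter) as a modest move beyond the scatter, when a seven-membered non-aromatic ring replaced a six-membered one. Among the measured compounds shown here, compound 3 returns to a six-membered non-aromatic ring, but one with 2 hetero atoms, and no measured compound shows what that exchange does. A step of similar size towards slower removal is therefore expected, with wide uncertainty. The expected change is a 2.0-fold lower number from compound 2 to compound 3 (0.29 log units; within the scatter) on this reasoning. For compound 3 the estimated value is 20 mL.min-1.g-1 with an expected range from 9 mL.min-1.g-1 to 45 mL.min-1.g-1 in this assay.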

Compound 3, intrinsic clearance in microsomes: < 3 mL.min-1.g-1
Compound 3: only a limit was reported; the forecaster's own chance of this, stated with the estimate: 3%; at least 6.6-fold (0.82 log units) between middle value and limit.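

In this assay, the group on this aromatic carbon, opposite the ring nitrogen, can shift the number much further than the earlier pair showed: the exchange gives an at least 13-fold lower number from compound 2 to compound 3 (1.11 log units; beyond the scatter). Ring size alone does not settle the matter, since a six-membered non-aromatic ring with 2 hetero atoms, rather than 1, still gives an at least 5.6-fold lower number from compound 1 to compound 3 (0.75 log units; beyond the scatter). The result for compound 3 is a limit, not a number: the limit of < 3 mL.min-1.g-1 in this assay, at which 1 of the 3 values shown sits.

The compounds shown leave open whether the step belongs to the added ring nitrogen itself or to the methyl group it carries. A ring with an unsubstituted amine at that point, or with an oxygen atom in its place, would separate these two possibilities.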